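Second trifluoromethyl group: from compound 3 to compound 4

The compounds below may be only part of what the source reports. "The series", "measured", "known", "first", "only" and "open" are said of these compounds alone.

Measured in a functional assay on MDA-MB-231 cells (Homo sapiens) for inhibition, read by MTT assay, with a stated time of 48 h; a higher number here means a weaker inhibitor of growth, a lower number a stronger inhibitor of growth:
compound 1 `S=C(Nc1ccccc1)Nc1ccc2ncnc(Nc3cccc(Br)c3)c2c1`: 10000 nM
compound 2 `Fc1ccc(NC(=S)Nc2ccc3ncnc(Nc4cccc(Br)c4)c3c2)cc1Cl`: 300 nM
compound 3 `FC(F)(F)c1cccc(NC(=S)Nc2ccc3ncnc(Nc4cccc(Br)c4)c3c2)c1`: 1400 nM

Compound 3 sits in the middle of these three values. The gap to the lower side is a 4.7-fold higher number from compound 2 to compound 3 (0.67 log units; beyond the scatter), and the gap to the higher side is a 7.1-fold lower number from compound 1 to compound 3 (0.85 log units; beyond the scatter), both modest.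

Compound 4 `FC(F)(F)c1cc(NC(=S)Nc2ccc3ncnc(Nc4cccc(Br)c4)c3c2)cc(C(F)(F)F)c1` is still unmeasured. It differs from compound 3 by trifluoromethyl in place of hydrogen on an aromatic carbon, which places trifluoromethyl in place of hydrogen on an aromatic carbon.

Among the compounds with values here, the closest precedent is the same replacement, a 7.1-fold lower number from compound 1 to compound 3 (0.85 log units; beyond the scatter), a modest step toward lower numbers. Also relevant is a 33-fold lower number from compound 1 to compound 2 (1.52 log units; beyond the scatter), a large step that shows how far a substituted phenyl can move the value in this assay. Within the data shown here, no measured pair tests a second trifluoromethyl group, so the first step cannot simply be repeated. A smaller step in the same direction seems most likely, with a result near compound 3 still possible.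

The expected step is a 2.3-fold lower number from compound 3 to compound 4 (0.37 log units; beyond the scatter). For compound 4 the estimated value is 600 nM, with an expected range of 200 nM to 2500 nM.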

Compound 4, concentration for 50% growth inhibition: 800 nM
Compound 4: the middle estimate sits 1.3-fold (0.12 log units) below what was measured; the measured number falls inside the stated range.
By their numbers in this assay, from the lowest: compound 2; then compounds 4 and 3 (each within the scatter of the next); then compound 1.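

Trifluoromethyl in place of hydrogen on an aromatic carbon, here meta to a trifluoromethyl group, gives a 1.8-fold lower number from compound 3 to compound 4 (0.24 log units; within the scatter) in this assay and so shows no clear change at this position. The same replacement at the first trifluoromethyl position gives a 7.1-fold lower number from compound 1 to compound 3 (0.85 log units; beyond the scatter) and lies beyond the scatter, so the effect of the first group does not repeat with the second in this pair. No measurement on hand accounts for the contrast between these two steps.

From the compounds shown here alone, it remains open whether an amine or a carboxylic acid at this position would shift the growth-inhibition value beyond the scatter. Also open, going by these compounds, is whether a second trifluoromethyl group would behave the same way on a ring that carries other substituents, such as the chlorine and fluorine of compound 2.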